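From hydroxy to fluoro in a growth inhibition series

The compounds below may be only part of what the source reports. "The series", "measured", "known", "first", "only" and "open" are said of these compounds alone.

In a functional assay on OVCAR-4 cells (Homo sapiens) for inhibition (on this read-out lower numbers stand for stronger inhibition of growth and higher numbers for weaker inhibition of growth), compound 1 (`COc1ccc(-n2cnnc2-c2cc(OC)c(OC)c(OC)c2)cc1`) gives 5500 nM, while compound 2 (`COc1ccc(-n2cnnc2-c2cc(OC)c(OC)c(OC)c2)cc1O`) gives 417 nM, the lower of the two numbers. Compound 3 (`COc1ccc(-n2cnnc2-c2cc(OC)c(OC)c(OC)c2)cc1F`) has not yet been measured. It carries fluoro in place of hydroxy on an aromatic carbon, ortho to a methoxy group and meta to a large group: fluoro in place of hydroxy on an aromatic carbon. For the measured compounds named here, only one measured step bears on this change. Adding the same hydroxy gave a 13-fold lower number from compound 1 to compound 2 (1.12 log units; beyond the scatter), a large step beyond the scatter, with hydroxy in place of hydrogen on an aromatic carbon. Going by the values given here, compound 3 lacks that hydroxy, so much of this gain is expected to be lost, although no measurement yet shows how fluoro compares with hydrogen here. The expected change is a 3.6-fold higher number from compound 2 to compound 3 (0.56 log units; beyond the scatter), toward weaker inhibition of growth. Compound 3 is estimated at 1500 nM, with an expected range of 350 nM to 6500 nM.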

Compound 3, concentration for 50% growth inhibition: 5250 nM
Compound 3: middle estimate off by 3.5-fold (0.54 log units), on the low side; measured number inside the range.
By their numbers in this assay, from the lowest: compound 2; then compounds 3 and 1 (each within the scatter of the next).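

In this assay, fluoro in place of hydroxy gives a 13-fold higher number from compound 2 to compound 3 (1.10 log units; beyond the scatter), so fluoro does not retain the gain that hydroxy brought at this position on the aromatic carbon. Fluoro in place of hydrogen gives a 1.0-fold lower number from compound 1 to compound 3 (0.02 log units; within the scatter), which lies within the scatter, so fluoro and hydrogen cannot be told apart here, and among the three groups shown only hydroxy stands apart. No measured evidence is available to explain why hydroxy stands apart from the other two groups.

The compounds shown leave open how an amino group or a carboxylic acid in the same place would compare with hydroxy. They also leave open whether chloro would track fluoro and hydrogen, or whether a hydroxymethyl group would track hydroxy.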